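Adding 4-carboxypiperidin-1-yl to compound 3

The compounds below may be only part of what the source reports. "The series", "measured", "known", "first", "only" and "open" are said of these compounds alone.

Of the compounds shown here, three have been read so far in an ADME assay for permeability, using PAMPA, at pH 7.4 (on this read-out higher numbers stand for higher permeability and lower numbers for lower permeability), for now. Compound 1 `Cc1ccc(-c2nc3ccccc3s2)cc1NC(=O)c1cc([N+](=O)[O-])c(N2CCC(C(=O)O)CC2)cc1Cl` gives 17 10^-6 cm/s in this read-out, and compound 2 `O=C(Nc1cccc(-c2nc3ccccc3s2)c1)c1cc([N+](=O)[O-])ccc1Cl` gives 12 10^-6 cm/s there. These two values lie within the usual scatter of each other.

Compound 3 `COc1ccc(-c2nc3ccccc3s2)cc1NC(=O)c1cc([N+](=O)[O-])ccc1Cl` has only the entry "below limit of detection" (no number reported) and no number. It therefore offers no value from which to measure a step.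

Compound 4 `COc1ccc(-c2nc3ccccc3s2)cc1NC(=O)c1cc([N+](=O)[O-])c(N2CCC(C(=O)O)CC2)cc1Cl` is compound 3 with one change: 4-carboxypiperidin-1-yl in place of hydrogen on an aromatic carbon in short, 4-carboxypiperidin-1-yl in place of hydrogen on an aromatic carbon, ortho to a nitro group and para to a large group.

Going by the values given here, no measured pair shows this step in this assay directly. The expected direction is upward, from an entry without a number to a readable number, and the size of the step cannot be stated while compound 3 has no number. This expectation rests on compound 1, which also carries 4-carboxypiperidin-1-yl and gives 17 10^-6 cm/s in that read-out. Against any simple rule, compound 2 lacks that group and still gives 12 10^-6 cm/s as a number. A second entry without a number remains possible.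

For compound 4 the expected value is 10 10^-6 cm/s with 2 10^-6 cm/s to 30 10^-6 cm/s as the estimated range.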

Compound 4, apparent permeability: 5 10^-6 cm/s
Estimate against measurement, compound 4: 2.0-fold (0.30 log units) above; the measured number falls inside the stated range.
By their numbers in this assay, from the lowest: compound 4; then compounds 2 and 1 (each within the scatter of the next).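

In this assay compound 4, with 4-carboxypiperidin-1-yl in place of hydrogen on an aromatic carbon ortho to a nitro group, gives 5 10^-6 cm/s as a readable number, whereas compound 3 has no number and the step between these two compounds cannot be read. With 4-carboxypiperidin-1-yl present in both compounds, methoxy in place of methyl on an aromatic carbon gives a 3.4-fold lower number from compound 1 to compound 4 (0.53 log units; beyond the scatter) and is a modest change that compound 3 alone could not show. The data at hand offer no measured basis for explaining either observation.

Going by these compounds, it remains open whether the readable number of compound 4 depends on the carboxylic acid or on the piperidine ring that carries it, a question that a primary amine or a methyl ester at that ring carbon would address. Also open, on these data alone, is how far the step at the other position extends beyond methyl and methoxy, for instance to ethyl or hydroxyl on the same aromatic carbon, and whether it holds when hydrogen replaces 4-carboxypiperidin-1-yl.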